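The source may hold more compounds than are shown below. What is called first, only, known or untested is meant among the compounds shown, and "the series" means these compounds.

In an ADME assay on H9 cells (Homo sapiens) for cytotoxicity, read by XTT assay, with a stated time of 6 days (on this read-out higher numbers stand for lower toxicity in this test and lower numbers for higher toxicity in this test), compound 3 (`Cc1cc(C#N)cc(C)c1Oc1cc(Nc2ccc(C#N)cc2)c([N+](=O)[O-])cc1[N+](=O)[O-]`) gives > 58200 nM, which is a limit of the assay and not a number. Compound 1 (`Cc1cc(C)c(Oc2cc(Nc3ccc(C#N)cc3)c(N)cc2[N+](=O)[O-])c(C)c1`) reads 32200 nM. Compound 2 (`Cc1cc(C#N)cc(C)c1Oc1cc(Nc2ccc(C#N)cc2)c(N)cc1N`) reads 51000 nM, within the usual scatter of compound 1. Compound 4 (`Cc1cc(C#N)cc(C)c1Oc1cc(Nc2ccc(C#N)cc2)c(N)cc1[N+](=O)[O-]`) differs from compound 3 by one change, amino in place of nitro on an aromatic carbon, ortho to a (4-cyanophenyl)amino group: amino in place of nitro on an aromatic carbon. Compound 1, which carries the same amino and nitro pair, stands at 32200 nM, so a small move towards lower numbers in this assay is expected, not far beyond the scatter. The expected step is an at least 1.5-fold lower number from compound 3 to compound 4 (0.18 log units; that floor lies within the scatter). Compound 4 is estimated at 38000 nM, with an expected range of 14000 nM to 70000 nM.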

Compound 4, half-maximal cytotoxic concentration: 62700 nM
Compound 4: the middle estimate sits 1.7-fold (0.22 log units) below what was measured; measured number inside the range.
By their numbers in this assay, from the lowest: compounds 1, 2 and 4 (each within the scatter of the next).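

In this assay, the value of compound 3 is a limit and not a number, so the step for amino in place of nitro at this position cannot be read: the limit of > 58200 nM in this assay, at which 1 of the 4 values shown sits. Nitro in place of amino on an aromatic carbon gives a 1.2-fold higher number from compound 2 to compound 4 (0.09 log units; within the scatter) and cyano in place of methyl on an aromatic carbon gives a 1.9-fold higher number from compound 1 to compound 4 (0.29 log units; within the scatter), so neither change moves the number beyond the scatter. The compounds shown leave open whether another group at this position, such as a carboxylic acid or a methoxy group, would do so.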